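A few compounds are considered here, and "the series" means these few. Any claim that something is new, unique, unknown or untested is made for them only; others in the source may bear on it.

For the measured compounds named here, compound 3 `COc1cc(N)c(Cl)cc1C(=O)NC1CCN(CCCCCO)CC1` gives the lowest number of the three measured so far: in a functional assay on HEK293 cells for agonist activity at 5-hydroxytryptamine receptor 4 (Homo sapiens), read by cAMP accumulation (on this read-out higher numbers stand for an effect only at larger amounts of compound and lower numbers for an effect already at smaller amounts), compound 3 gives 15.9 nM, whereas compound 2 `CCN1CCC(NC(=O)c2cc(Cl)c(N)cc2OC)CC1` gives 79.4 nM and compound 1 `COc1cc(N)c(Cl)cc1C(=O)NC1CCNCC1` gives 398 nM. All measured steps change the substituent on the amine nitrogen in the ring: a 5.0-fold lower number from compound 1 to compound 2 (0.70 log units; beyond the scatter) with ethyl in place of hydrogen, a 25-fold lower number from compound 1 to compound 3 (1.40 log units; beyond the scatter) with 5-hydroxypentyl in place of hydrogen, and a 5.0-fold lower number from compound 2 to compound 3 (0.70 log units; beyond the scatter) on going from ethyl to 5-hydroxypentyl. Compound 4 `COc1cc(N)c(Cl)cc1C(=O)NC1CCN(CCCCCN2C(=O)c3ccccc3C2=O)CC1` carries a group of 11 heavy atoms (8 carbon, 1 nitrogen, 2 oxygen; one five-membered non-aromatic ring with 1 hetero atom, one six-membered aromatic ring of carbon only) in place of one oxygen atom, on a saturated chain carbon, five bonds along the chain from an amine nitrogen in a ring. Going by the values given here, no measured step removes a hydroxy or introduces a group of this kind, so the bearing of the earlier steps is indirect; they show only that lengthening the chain on that nitrogen lowered the number. The expected step from compound 3 to compound 4 is a 1.1-fold lower number from compound 3 to compound 4 (0.03 log units; within the scatter), within the scatter. Compound 4 is estimated at 15 nM, range 4 nM to 60 nM.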

Compound 4, half-maximal effective concentration: 5.01 nM
Compound 4: middle estimate off by 3.0-fold (0.48 log units), on the high side; measured number inside the range.
By their numbers in this assay, from the lowest: compound 4; then compound 3; then compound 2; then compound 1.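

The place on a saturated chain carbon, five bonds along the chain from an amine nitrogen in a ring, accepts far more than a hydroxy: the group of 11 heavy atoms there gives a 3.2-fold lower number from compound 3 to compound 4 (0.50 log units; beyond the scatter) and the number does not rise. Within this pair, a hydrogen-bond donor at the chain end is therefore not needed for a low number. Nothing measured here accounts for the step.

Still open, going by these compounds, is which part of the entering group carries the step: the aromatic ring, the carbonyls or the five-membered ring. A primary amine, a plain phenyl or a longer chain at this place could separate these.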